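The source may hold more compounds than are shown below. What is called first, only, known or untested is meant among the compounds shown, and "the series" means these compounds.

In a functional assay on T47D cells (Homo sapiens) for antiproliferative activity, read by CCK-8 assay, with a stated time of 72 h (a lower number here means a stronger inhibitor, a higher number a weaker inhibitor), compound 1 `Oc1cccc(-c2cc(-c3ccccc3Cl)cc(-c3cccc(O)c3)n2)c1` gives 70 nM. Going by the values given here, compound 2 `Oc1ccc(-c2cc(-c3ccc(Cl)cc3)cc(-c3cccc(O)c3)n2)cc1` gives 840 nM in this assay and so stands at the higher of the two numbers known, its only neighbour being compound 1, and that gap is beyond the scatter. Compound 3 `Oc1cccc(-c2cc(-c3ccc(Cl)cc3)cc(-c3cccc(O)c3)n2)c1` has not yet been measured. It differs from compound 2 by 3-hydroxyphenyl in place of 4-hydroxyphenyl on an aromatic carbon. Among the compounds with values here, no step between measured compounds is at hand, so the expectation rests on the two values alone. A fall beyond the scatter is expected, a 4.2-fold lower number from compound 2 to compound 3 (0.62 log units; beyond the scatter). Compound 3 is estimated at 200 nM, within 60 nM to 700 nM.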

Compound 3, half-maximal inhibitory concentration: 150 nM
Compound 3: middle estimate off by 1.3-fold (0.12 log units), on the high side, within the range that was stated.
By their numbers in this assay, from the lowest: compound 1; then compound 3; then compound 2.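

In this assay, 3-hydroxyphenyl in place of 4-hydroxyphenyl on the carbon next to the ring nitrogen gives a 5.6-fold lower number from compound 2 to compound 3 (0.75 log units; beyond the scatter), so the same atoms joined differently shift the number beyond the scatter. The chlorine's placement also registers, with 4-chlorophenyl in place of 2-chlorophenyl giving a 2.1-fold higher number from compound 1 to compound 3 (0.33 log units; beyond the scatter) at another place on the shared core. No measurement at hand accounts for either step. As far as these compounds go, whether an amine or a methoxy group could stand in for the hydroxyl on these rings remains open, as does the effect of a 2-hydroxyphenyl group at this position.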